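A few compounds are considered here, and "the series" means these few. Any claim that something is new, unique, unknown or untested is made for them only; others in the source may bear on it.

Measured compounds:
- compound 1, `c1ccc(CN2CCN(CCCc3c[nH]c4ccc(-n5cnnc5)cc34)CC2)nc1`, gives 0.4 nM in an assay on CHO cells for displacement of a labelled ligand from 5-hydroxytryptamine receptor 1D (Homo sapiens); a lower number here means a stronger inhibitor, a higher number a weaker inhibitor
- compound 2, `c1c[nH]c(CN2CCN(CCCc3c[nH]c4ccc(-n5cnnc5)cc34)CC2)n1`, gives 1.6 nM in this assay
- compound 3, `c1cnc(N2CCN(CCCc3c[nH]c4ccc(-n5cnnc5)cc34)CC2)nc1`, gives 0.6 nM in this assay

Compound 1 has the lowest of the three numbers; compound 3 is within the scatter of it, compound 2 lies beyond. Compound 4, `c1ccc(CCCN2CCN(CCCc3c[nH]c4ccc(-n5cnnc5)cc34)CC2)cc1`, differs from compound 1 in this way: phenethyl in place of pyridin-2-yl on a saturated chain carbon bound to an amine nitrogen in a ring. For the measured compounds named here, two measured steps bear on this change. Swapping the ring on that chain carbon gave a 4.0-fold higher number from compound 1 to compound 2 (0.60 log units; beyond the scatter), while a change of the whole group on the ring nitrogen gave a 1.5-fold higher number from compound 1 to compound 3 (0.18 log units; within the scatter). Replacing the ring and lengthening the chain is therefore expected to cost a modest amount, a 3.8-fold higher number from compound 1 to compound 4 (0.57 log units; beyond the scatter). Compound 4 is estimated at 1.5 nM, with a range from 0.4 nM to 6 nM.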

Compound 4, half-maximal inhibitory concentration: 4.9 nM
Compound 4: middle estimate off by 3.3-fold (0.51 log units), on the low side, within the range that was stated.
By their numbers in this assay, from the lowest: compounds 1 and 3 (each within the scatter of the next); then compound 2; then compound 4.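

For the compounds shown here, on the saturated chain carbon bound to an amine nitrogen in a ring, phenethyl in place of pyridin-2-yl is the first large step (a 12-fold higher number from compound 1 to compound 4 (1.09 log units; beyond the scatter)). The 3-phenylpropyl group also separates compound 4 from the other two compounds (an 8.2-fold higher number from compound 3 to compound 4 (0.91 log units; beyond the scatter)) and (a 3.1-fold higher number from compound 2 to compound 4 (0.49 log units; beyond the scatter)), so that this position is not indifferent to every group placed on it. Nothing measured here explains these losses.

As far as these compounds go, this change alters the ring and the chain length together, so the share of each remains open. Benzyl on the ring nitrogen, or pyridin-2-yl on a longer chain, would be needed to separate them.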